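This account rests on a few compounds, and the source may have more. Where it says the series, first, only, none or still open, it means among the compounds named here.

Series notes. Compound 1 `COc1cc(C)c(S(N)(=O)=O)cc1C(=O)Nc1cccc(-c2nncn2C(C)C)n1` and compound 2 `COc1ccc(S(C)(=O)=O)cc1C(=O)Nc1cccc(-c2nncn2C(C)C)n1` share one core and differ only in the groups carried on one aromatic ring. In an assay for inhibition of serine/threonine-protein kinase Sgk1 (Homo sapiens), tested at 1 uM (on this read-out higher numbers stand for more inhibition at the one concentration tested (going by the name of the read-out) and lower numbers for less inhibition), compound 1 gives 1%, and in this assay compound 2 gives 2%. Among the measured compounds shown here, these two values lie within the usual scatter of each other, so compound 2 cannot be set apart from compound 1 on the numbers so far, and both sit close to no inhibition.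

Compound 3 `COc1cc(C)c(S(C)(=O)=O)cc1C(=O)Nc1cccc(-c2nncn2C(C)C)n1` is not yet measured. It differs from compound 2 by methyl in place of hydrogen on an aromatic carbon. For the measured compounds named here, no measured pair shows this change on its own, so no step size is known for it. Compound 1, which also carries a methyl, gives 1% in this assay, and compound 2 gives 2%, so nothing in the data points away from low inhibition. The step of a number 1 percentage points higher from compound 2 to compound 3 (within the scatter) is expected to be none beyond the scatter. Compound 3 is therefore estimated at 3% in this assay, with a range of -5% to 12%.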

Compound 3, a percentage reported as inhibition, at one concentration (the size of the read-out at that concentration, not a potency): 1%
Beside the measured number, compound 3's estimate is 2 percentage points above it; the measured number falls inside the stated range.
By their numbers in this assay, from the lowest: compounds 1, 3 and 2 (each within the scatter of the next).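

In this assay, among the compounds shown here, methyl in place of hydrogen on the aromatic carbon ortho to a methylsulfonyl group and para to a large group gives a number 1 percentage points lower from compound 2 to compound 3 (within the scatter) and so, for the first time, this position has a direct reading for this change, one that lies within the scatter. Methyl in place of amino on a sulfonyl sulfur, with the aromatic methyl present in both compounds, gives no change at the digits printed from compound 1 to compound 3 (within the scatter) as a second step within the scatter, and compound 1, compound 2 and compound 3 all sit close to no inhibition. No measurement on hand bears on why these readings fall where they do.

With all three readings this close to no inhibition, neither place has yet been shown to affect the read-out. On these data alone, it remains open whether an amine or a carboxylic acid on that aromatic carbon, or a longer chain on the sulfonyl sulfur, would read differently.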